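The compounds below may be only part of what the source reports. "The series", "measured", "known", "first", "only" and "open" are said of these compounds alone.

Working notes on the series in an ADME assay on microsomes from liver (Mus musculus) for metabolic stability; a higher number here means faster removal of the compound, a lower number slower removal. Compound 2 `O=C(O)Cn1nc(Cc2nc3cc(F)c(OCC4CC4)cc3[nH]2)c2ccccc2c1=O` has no exact reading so far: its result is a limit of the assay, < 53.4 mL/min/kg. Compound 1 `CCOc1cc2[nH]c(Cc3nn(CC(=O)O)c(=O)c4ccccc34)nc2cc1Cl`, which has the shared core and carries a chloro group, likewise gives only a limit, < 51.7 mL/min/kg. Going by the values given here, compound 3 `O=C(Cc1nn(C2CC2)c(=O)c2ccccc12)Nc1ccc(OC(F)(F)F)c(Cl)c1` gives the only true number in the set, 2300 mL/min/kg.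

Compound 4 `O=C(O)Cn1nc(Cc2nc3cc(Cl)c(OCC4CC4)cc3[nH]2)c2ccccc2c1=O` comes from compound 2 with chloro in place of fluoro on an aromatic carbon, ortho to a cyclopropylmethoxy group: chloro in place of fluoro on an aromatic carbon. Among the compounds with values here, no measured pair isolates this change. The expectation therefore leans on compound 1, whose limit of < 51.7 mL/min/kg was reached with a chloro group present. No shift beyond the scatter is expected in this assay. The expected step that the limit leaves unreadable from compound 2 to compound 4 is an estimate only, and another report as a limit is likely. The estimate for compound 4 is 50 mL/min/kg, with an expected range from 25 mL/min/kg to 110 mL/min/kg.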

Compound 4, clearance: 147 mL/min/kg
Compound 4: middle estimate off by 2.9-fold (0.47 log units), on the low side; the measured number lies above the stated range.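

In this assay, the position ortho to the cyclopropylmethoxy group proves not to be silent: chloro in place of fluoro on an aromatic carbon gives an at least 2.7-fold higher number from compound 2 to compound 4 (0.43 log units; beyond the scatter). With the chloro group held, cyclopropyl in place of methyl on a saturated chain carbon bound to an oxygen on an aromatic ring gives an at least 2.8-fold higher number from compound 1 to compound 4 (0.45 log units; beyond the scatter), so among the compounds on the shared core, the true number appears only where chloro and cyclopropylmethoxy occur together. The first step is known only as a minimum because compound 2 stands at a limit: the limit of < 53.4 mL/min/kg in this assay, at which 1 of the 4 values shown sits.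

As far as these compounds go, the true size of the second step stays open because compound 1 also stands at a limit: the limit of < 51.7 mL/min/kg in this assay, at which 1 of the 4 values shown sits. Also open is whether a bromo group or a nitrile at this position would follow chloro or fluoro in this setting.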